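Propanoylamino analogue of compound 3: expected tolerance

The compounds below may be only part of what the source reports. "The series", "measured", "known", "first", "only" and "open" are said of these compounds alone.

Compound 3 `Cn1c(-c2ccc(N)cc2)nc2cc(C(F)(F)F)ccc21` is one of three members of this series measured in an ADME assay on MT4 cells (Homo sapiens) for cytotoxicity, read by MTT assay, with a stated time of 96 h; a lower number here means that less compound is tolerated, a higher number that more compound is tolerated. Compound 3 gives 20000 nM, the highest of the three numbers shown, though all three lie within the scatter of one another. Compound 1 `CCC(=O)Nc1ccc(-c2nc3cc(C(F)(F)F)ccc3n2C2CCCCC2)cc1`, which carries a propanoylamino group, gives 17000 nM in this assay. The acetyl counterpart of compound 3 is compound 2 `CC(=O)Nc1ccc(-c2nc3cc(C(F)(F)F)ccc3n2C)cc1`, and compound 2 gives 15000 nM. Going by the values given here, the only single-change step among the measured compounds is a 1.3-fold higher number from compound 2 to compound 3 (0.12 log units; within the scatter), so exchanging acetyl for hydrogen on a nitrogen on an aromatic ring left the number essentially unchanged.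

Compound 4 `CCC(=O)Nc1ccc(-c2nc3cc(C(F)(F)F)ccc3n2C)cc1` differs from compound 3 as follows: propanoyl in place of hydrogen on a nitrogen on an aromatic ring. The step from compound 2 to compound 3 bears directly on this change, since a propanoyl group is the close relative of the acetyl group at the same kind of nitrogen, and that step stayed within the scatter; compound 1, which also carries the propanoyl group, likewise sits within the scatter of compound 3. No step beyond the scatter is therefore expected for compound 4 in this assay, the estimated step being a 1.3-fold lower number from compound 3 to compound 4 (0.10 log units; within the scatter). Compound 4 is expected to give 16000 nM, with a range from 9000 nM to 28000 nM.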

Compound 4, half-maximal cytotoxic concentration: 8000 nM
Compound 4: the middle estimate sits 2.0-fold (0.30 log units) above what was measured; measured number below the stated range.
By their numbers in this assay, from the lowest: compounds 4, 2, 1 and 3 (each within the scatter of the next, the first and the last beyond it).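

In this assay the propanoyl group on a nitrogen on an aromatic ring gives a 2.5-fold lower number from compound 3 to compound 4 (0.40 log units; beyond the scatter) and so a step beyond the scatter, which the acetyl group at the same kind of nitrogen did not give in a 1.3-fold higher number from compound 2 to compound 3 (0.12 log units; within the scatter) on the same core. Methyl in place of hydrogen on a saturated chain carbon bound to a carbonyl carbon gives a 1.9-fold lower number from compound 2 to compound 4 (0.27 log units; within the scatter) and so does not separate the propanoyl from the acetyl compound. With the propanoylamino group held fixed, methyl in place of cyclohexyl on an aromatic nitrogen gives a 2.1-fold lower number from compound 1 to compound 4 (0.33 log units; beyond the scatter) as a second modest step, so compound 1 did not stand in for compound 4.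

Open, going by these compounds, is whether a butanoyl group or a chain ending in an amine on the same nitrogen, or ethyl on the aromatic nitrogen, would shift the number further. Nothing at hand bears on the reason for these steps.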